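A few compounds are considered here, and "the series" means these few. Any claim that something is new, unique, unknown or untested is made for them only; others in the source may bear on it.

Working notes on the series. Compound 1 `CCCCN(C)S(=O)(=O)NC(=O)Nc1c(C(C)C)cccc1C(C)C` in an assay on liver for inhibition of sterol O-acyltransferase 1 (Rattus norvegicus), using microsomes (on this read-out lower numbers stand for stronger inhibition and higher numbers for weaker inhibition), gives 2300 nM. Compound 2 `CCCCN(CC)S(=O)(=O)NC(=O)Nc1c(C(C)C)cccc1C(C)C` in this assay gives 1200 nM. Among the measured compounds shown here, the one step measured so far, a 1.9-fold lower number from compound 1 to compound 2 (0.28 log units; within the scatter), is a methyl in place of hydrogen on a saturated chain carbon bound to a sulfonamide nitrogen. Compound 1 therefore stands at the highest of the two numbers, and its nearest neighbour, compound 2, sits within the scatter of it.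

Compound 3 `CC(C)c1cccc(C(C)C)c1NC(=O)NS(=O)(=O)N1CCCCC1` has not been measured in this assay. Against compound 1 the change is piperidin-1-yl in place of butyl(methyl)amino on a sulfonyl sulfur. For the measured compounds named here, the only measured step that touches the group on the sulfonyl sulfur is that from compound 1 to compound 2, and it stayed within the scatter; no other step bears on this change. On that basis no step beyond the scatter is expected in this assay in either direction, with the middle of the expectation set a little under compound 1 because of a 1.9-fold lower number from compound 1 to compound 2 (0.28 log units; within the scatter). The estimated step is a 1.4-fold lower number from compound 1 to compound 3 (0.13 log units; within the scatter). For compound 3 the estimate in this assay is 1700 nM, with a range from 600 nM to 5000 nM.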

Compound 3, half-maximal inhibitory concentration: 17000 nM
Beside the measured number, compound 3's estimate is 10-fold (1.00 log units) below it, and the stated range ends below it.
By their numbers in this assay, from the lowest: compounds 2 and 1 (each within the scatter of the next); then compound 3.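

In this assay, piperidin-1-yl in place of butyl(methyl)amino on a sulfonyl sulfur gives a 7.4-fold higher number from compound 1 to compound 3 (0.87 log units; beyond the scatter), and in place of butyl(ethyl)amino it gives a 14-fold higher number from compound 2 to compound 3 (1.15 log units; beyond the scatter). This position is therefore not indifferent to change: the earlier step between the two open-chain groups stayed within the scatter, whereas tying the same heavy atoms of butyl(methyl)amino into a ring moves the number beyond the scatter, towards weaker inhibition. No measurement at hand bears on why the ring form behaves this way.

As far as these compounds go, whether the higher number goes with rings on the sulfonyl sulfur in general or with piperidin-1-yl alone stays open; pyrrolidin-1-yl, morpholin-4-yl or an open chain such as dibutylamino at this place would help to separate those readings. The compounds shown also all keep the shared core unchanged, so whether the ring carries a step of similar size on another core remains open as well.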